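The compounds below may be only part of what the source reports. "The series", "measured", "known", "first", "only" and "open" are said of these compounds alone.

Of the compounds shown here, three have been measured in a functional assay (brain) for displacement of a labelled ligand, with Rattus norvegicus as the target (a lower number here means a stronger inhibitor, a higher number a weaker inhibitor), and a fourth, compound 4 `C[C@H](N)[C@H]1COC(c2ccccc2)(c2ccccc2)O1`, is still to be tested there.

Compound 1 `CN1CCCC[C@H]1[C@H]1COC(c2ccccc2)(c2ccccc2)O1` gives 4400 nM in this assay. Compound 2 `CCN1CCCC[C@H]1[C@H]1COC(c2ccccc2)(c2ccccc2)O1` gives 6900 nM in this assay; the step of a 1.6-fold higher number from compound 1 to compound 2 (0.20 log units; within the scatter) is too small to count as a real change. Compound 3 `NC[C@H]1COC(c2ccccc2)(c2ccccc2)O1` gives 1400 nM in this assay, the lowest number of the three, with a 3.1-fold lower number from compound 1 to compound 3 (0.50 log units; beyond the scatter) and a 4.9-fold lower number from compound 2 to compound 3 (0.69 log units; beyond the scatter) both beyond the scatter.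

Compound 4 differs from compound 3 by methyl in place of hydrogen on a saturated chain carbon bound to an amine nitrogen and a saturated ring carbon. The closest measured precedent is the step from compound 1 to compound 2, which also placed a methyl on a saturated chain carbon bound to an amine nitrogen, and there the step of a 1.6-fold higher number from compound 1 to compound 2 (0.20 log units; within the scatter) stayed within the scatter. Among the measured compounds shown here, no other measured step touches the same kind of position. On that basis a small change, if any, is expected for compound 4, with a slight lean toward a higher number, so the estimated step is a 1.4-fold higher number from compound 3 to compound 4 (0.13 log units; within the scatter). Compound 4 is therefore expected to give about 1900 nM in this assay, most likely somewhere between 600 nM and 6000 nM.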

Compound 4, inhibition constant: 607 nM
Compound 4: middle estimate off by 3.1-fold (0.50 log units), on the high side, and the stated range covers the measured number.
By their numbers in this assay, from the lowest: compound 4; then compound 3; then compounds 1 and 2 (each within the scatter of the next).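

In this assay, methyl in place of hydrogen on a saturated chain carbon bound to an amine nitrogen and a saturated ring carbon produces a real gain, a 2.3-fold lower number from compound 3 to compound 4 (0.36 log units; beyond the scatter), so this position responds to even a single added carbon. The same small group also widens the distance from the larger groups: 1-aminoethyl in place of 1-ethylpiperidin-2-yl gives an 11-fold lower number from compound 2 to compound 4 (1.06 log units; beyond the scatter), and 1-aminoethyl in place of 1-methylpiperidin-2-yl gives a 7.2-fold lower number from compound 1 to compound 4 (0.86 log units; beyond the scatter). The result from the earlier methyl step therefore does not carry over to this position, and the two steps point in different directions: the same change on two cores in this assay, a 1.6-fold higher number (0.20 log units; within the scatter) from compound 1 to compound 2 and a 2.3-fold lower number (0.36 log units; beyond the scatter) from compound 3 to compound 4, 3.6-fold (0.56 log units) apart, beyond the scatter of two such steps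

The compounds shown leave open whether a longer chain such as propyl, or a second methyl, on this same carbon would lower the number further or reverse the gain. They also cannot show why the same change behaves differently on the two cores, or whether a methyl on the amine nitrogen of compound 4 would keep its standing.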